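A Trimethoxyphenyl Swap on the Shared Core

The source may hold more compounds than are shown below. What is called first, only, known or untested is meant among the compounds shown, and "the series" means these compounds.

Compound 1 `COc1cc(/C=C/C(=O)c2cccc(-n3cc(-c4ccccc4)[nH]c3=O)c2)cc(OC)c1OC` is the stronger of two measured compounds in a functional assay on UACC-257 cells (Homo sapiens) for inhibition; on this read-out higher numbers stand for weaker inhibition of growth and lower numbers for stronger inhibition of growth: compound 1 gives 1520 nM, while compound 2 `COc1ccc(-c2cn(-c3cccc(C(=O)/C=C/c4ccc(O)c(OC)c4)c3)c(=O)[nH]2)cc1` gives 13300 nM, a gap beyond the usual scatter. Compound 3 `COc1cc(/C=C/C(=O)c2cccc(-n3cc(-c4cc(OC)c(OC)c(OC)c4)[nH]c3=O)c2)cc(OC)c1OC` differs from compound 1 in one place: 3,4,5-trimethoxyphenyl in place of phenyl on an aromatic carbon. Among the measured compounds shown here, no step between measured compounds mirrors this change, so the expectation rests on compound 1 alone. A modest move toward stronger inhibition is expected, though a result within the scatter would not surprise. Compound 3 is estimated at 900 nM, within a range from 300 nM to 2700 nM, which means an expected step of a 1.7-fold lower number from compound 1 to compound 3 (0.23 log units; within the scatter).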

Compound 3, concentration for 50% growth inhibition: 2220 nM
Beside the measured number, compound 3's estimate is 2.5-fold (0.39 log units) below it; the measured number falls inside the stated range.
By their numbers in this assay, from the lowest: compounds 1 and 3 (each within the scatter of the next); then compound 2.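

In this assay, putting 3,4,5-trimethoxyphenyl in place of phenyl on this aromatic carbon gives a 1.5-fold higher number from compound 1 to compound 3 (0.16 log units; within the scatter). This position of the shared core therefore takes a much larger group, and the read-out shows no difference beyond the scatter. Nothing available here speaks to the reason for this result. As far as these compounds go, whether a group of another kind at this position, such as an amine or a carboxylic acid, would leave the number in the same range stays open.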